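Replacing the Ester with Iodine on the Aryl Urea

The source may report more compounds than this note shows. Statements on the series, on what has been measured and on what is new or still open speak of the compounds shown alone.

Compound 1, `CCCCCc1ccc(NC(=O)N[C@@H](C)c2ccccc2)cc1`: 98%
Compound 2, `CCOC(=O)c1ccc(NC(=O)N[C@@H](C)c2ccccc2)cc1`: 99%

Two compounds share one urea core and differ at a single aromatic carbon. In an ADME assay on the whole organism with Oryza sativa as the target, tested at 0.1 uM (on this read-out higher numbers stand for a weaker effect at the one concentration tested and lower numbers for a stronger effect), compound 1 gives 98%, and compound 2 gives 99%. Both numbers sit close to the top of the percentage scale, meaning almost no effect at the concentration tested, and they lie within the scatter of each other. Among the compounds with values here, the only measured step, a number 1 percentage points higher from compound 1 to compound 2 (within the scatter), swaps pentyl for ethoxycarbonyl and changes nothing beyond the noise.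

Compound 3, `C[C@H](NC(=O)Nc1ccc(I)cc1)c1ccccc1`, follows from compound 2 by the change (iodo in place of ethoxycarbonyl on an aromatic carbon). Within the data shown here, the one step available bears on the same aromatic carbon and was flat, so for compound 3 no movement beyond the scatter is expected: a number 2 percentage points lower from compound 2 to compound 3 (within the scatter). Compound 3 is therefore estimated at 97%, with a range from 88% to 100%.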

Compound 3, a percentage reported as activity, at one concentration (the size of the read-out at that concentration, not a potency): 99%
Compound 3: the middle estimate sits 2 percentage points below what was measured; low and high end bracket the measured number.
By their numbers in this assay, from the lowest: compounds 1, 2 and 3 (each within the scatter of the next).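

Iodo, with 1 heavy atom and no hydrogen-bond acceptors, can take the place of ethoxycarbonyl, with 5 heavy atoms and 2 hydrogen-bond acceptors, on this aromatic carbon para to a large group, and this assay shows no change at the digits printed from compound 2 to compound 3 (within the scatter) for the swap. Set against the pentyl group, iodo gives the same picture, with a number 1 percentage points higher from compound 1 to compound 3 (within the scatter) as the step, so three quite different groups at this one position all leave the read-out near the top of the scale. No measurement at hand explains why this position stays so flat.

From the compounds shown here alone, whether any group here can bring the number down remains open, for example an amine, a carboxylic acid or a chain longer than pentyl. Also open, going by these compounds, is whether changes elsewhere on the shared core would move the read-out at all.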